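The source may report more compounds than this note shows. Statements on the series, on what has been measured and on what is new or still open speak of the compounds shown alone.

Compound 1 `O=c1cc(Nc2ccccc2)cc(-c2ccccc2)o1` serves as the reference point of the series. Among the measured compounds shown here, in a functional assay on KBVIN cells (Homo sapiens) for cytotoxicity, read by MTT assay, with a stated time of 72 h (a lower number here means that less compound is needed, a higher number that more compound is needed for the effect), compound 1 gives 0.15 uM, the lowest of the two numbers measured so far. For the measured compounds named here, compound 2 `COc1ccccc1Nc1cc(-c2ccccc2)oc(=O)c1` is the only other measured compound; in this assay compound 2 gives 0.49 uM. Going by the values given here, the single measured step, a 3.3-fold higher number from compound 1 to compound 2 (0.51 log units; beyond the scatter), came from a methoxy in place of hydrogen on an aromatic carbon.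

Compound 3 `O=c1cc(Nc2ccc(Br)cc2)cc(-c2ccccc2)o1` is not yet measured. It differs from compound 1 by bromo in place of hydrogen on an aromatic carbon, the change sitting para to a large group. Among the compounds with values here, the one available step, a 3.3-fold higher number from compound 1 to compound 2 (0.51 log units; beyond the scatter), concerns a different group on a different aromatic carbon, so it bears only loosely on this change; it does show that one small substituent can shift the number by a modest amount. For compound 3 a step of a 2.0-fold higher number from compound 1 to compound 3 (0.30 log units; within the scatter) is expected, a small rise or nothing beyond the scatter. Compound 3 is estimated at 0.3 uM, with a range from 0.1 uM to 0.9 uM.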

Compound 3, concentration for half-maximal effect: 0.24 uM
Compound 3: middle estimate off by 1.3-fold (0.10 log units), on the high side, within the range that was stated.
By their numbers in this assay, from the lowest: compounds 1 and 3 (each within the scatter of the next); then compound 2.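

The change from phenyl to 4-bromophenyl gives a 1.6-fold higher number from compound 1 to compound 3 (0.20 log units; within the scatter) in this assay and so shows that this ring can carry a bromo para to a large group without a step beyond the scatter. Among the compounds shown here, the methoxy of compound 2, on a different aromatic carbon, gave a 3.3-fold higher number from compound 1 to compound 2 (0.51 log units; beyond the scatter) and remains the only step beyond the scatter, so a substituent on this ring does not by itself move the number beyond the scatter. No measurement on hand explains why either step has the size it has.

From the compounds shown here alone, whether an amine, a carboxylic acid or a longer chain at this same place would also stay within the scatter of compound 1 remains open. Also open, going by these compounds, is how bromo would behave on the other carbons of this ring or on the second phenyl ring.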